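Methyl on the Phenolic Oxygen: Compound 3 Expected

The source may report more compounds than this note shows. Statements on the series, on what has been measured and on what is new or still open speak of the compounds shown alone.

Compound 1, `COc1ccc(-c2cc3ccccc3nc2/C=C/C(=O)c2ccccc2)cc1`: in a functional assay on A549 cells (Homo sapiens) for antiproliferative activity, read by XTT assay, with a stated time of 72 h (a lower number here means a stronger inhibitor, a higher number a weaker inhibitor), compound 1 gives 7410 nM.
Compound 2, `COc1ccc(-c2cc3ccccc3nc2/C=C/C(=O)c2ccc(O)cc2)cc1`: in this assay compound 2 gives 7440 nM.

Among the measured compounds shown here, compound 2 carries the higher of the two measured numbers, but its only neighbour, compound 1, sits within the usual scatter of it, since the step of a 1.0-fold higher number from compound 1 to compound 2 (0.00 log units; within the scatter) is essentially nil. Compound 3, `COc1ccc(C(=O)/C=C/c2nc3ccccc3cc2-c2ccc(OC)cc2)cc1`, differs from compound 2 by methyl in place of hydrogen on an oxygen on an aromatic ring. For the measured compounds named here, only one measured step exists in this set, and it concerns a hydroxy entering in place of hydrogen on the aromatic ring rather than a methyl placed on that oxygen; it showed no shift beyond the scatter. Going by the values given here, no measured step addresses the methyl-for-hydrogen change itself, so the data give no ground for a move in either direction. Compound 3 is therefore expected to behave like compound 2 in this assay, with a step of about a 1.0-fold lower number from compound 2 to compound 3 (0.00 log units; within the scatter), nothing beyond the scatter. The estimate for compound 3 in this assay is 7400 nM, with a range from 3000 nM to 18000 nM.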

Compound 3, half-maximal inhibitory concentration: 8500 nM
For compound 3 the middle estimate is 1.1-fold (0.06 log units) below the measured one, and the stated range covers the measured number.
By their numbers in this assay, from the lowest: compounds 1, 2 and 3 (each within the scatter of the next).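

In this assay, among the compounds shown here, methyl in place of hydrogen on an oxygen on an aromatic ring gives a 1.1-fold higher number from compound 2 to compound 3 (0.06 log units; within the scatter) and so adds the first measured change on that oxygen, one that turning hydroxy into methoxy leaves within the scatter. The methoxy gives a 1.1-fold higher number from compound 1 to compound 3 (0.06 log units; within the scatter) and, taken with a 1.0-fold higher number from compound 1 to compound 2 (0.00 log units; within the scatter) for the hydroxy, shows that hydrogen, hydroxy and methoxy at this place do not separate in this assay, which the two earlier compounds alone could show only for hydroxy. Nothing measured alongside these numbers bears on why the three compounds stay together.

On these data alone, whether an amine, a carboxylic acid or a longer chain such as butoxy at this place would move the number beyond the scatter stays open, for all three groups seen here give numbers that cannot be told apart. Also open, as far as these compounds go, is what the methoxy on the other aromatic ring and the rest of the shared core contribute, as these stay the same in compound 1, compound 2 and compound 3.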